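Moving a Methyl Around a Pyridazine Ring

A few compounds are considered here, and "the series" means these few. Any claim that something is new, unique, unknown or untested is made for them only; others in the source may bear on it.

Compound 1, `Cc1ccc(N2CCN(C(=O)Nc3nc4ccc(F)cc4s3)CC2)nn1`: > 10000 nM
Compound 2, `Cc1cc(N2CCN(C(=O)Nc3ccc(OC(F)(F)F)cc3)CC2)nnc1Cl`: > 10000 nM

In an assay on HEK293 cells for inhibition of transient receptor potential cation channel subfamily V member 1 (Homo sapiens), read by FLIPR, at pH 5.5 (on this read-out higher numbers stand for weaker inhibition and lower numbers for stronger inhibition), compound 1 gives > 10000 nM, which is a limit of the assay and not a number. Compound 2 in this assay likewise gives > 10000 nM, again only a limit. Within the data shown here, compound 1 therefore stands at the limit of the assay, and so does every other value shown (the limit of > 10000 nM in this assay, at which 2 of the 2 values shown sit); no measured step between two compounds exists here. Compound 3, `Cc1cnnc(N2CCN(C(=O)Nc3nc4ccc(F)cc4s3)CC2)c1`, has not yet been measured in this assay. It differs from compound 1 in 5-methylpyridazin-3-yl in place of 6-methylpyridazin-3-yl on an amine nitrogen in a ring, so the same atoms are kept and only the methyl group moves on the ring. With both known values sitting at the limit, no change beyond the usual scatter is expected, and the expected step is a step that the limit leaves unreadable from compound 1 to compound 3. Compound 3 is therefore estimated at about 15000 nM, in a range from 3000 nM to 60000 nM, most probably again reported only as a limit.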

Compound 3, half-maximal inhibitory concentration: > 10000 nM
Compound 3: no number, only a limit (the forecaster's own chance of this, stated with the estimate: 75%); the middle value does not contradict the limit.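

Compound 1 and compound 3 both give only a limit and not a number, so no step can be read between them. The compounds shown leave open how strongly any of them inhibits the channel, and whether moving the methyl changes that inhibition at all.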